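Cyano in place of chloro in compound 1

The source may report more compounds than this note shows. Statements on the series, on what has been measured and on what is new or still open speak of the compounds shown alone.

In an ADME assay on microsomes from liver (Rattus norvegicus) for metabolic stability, read by LC-MS, using NADPH, with a stated time of 10 min, tested at 0.5 uM (a higher number here means that more of the compound is left, a lower number that less of the compound is left), compound 1 (`COC(=O)Nc1cc(-c2cnc(OC[C@@](C)(N)CC(C)C)c(Cl)c2)ccn1`) shows 73% remaining and stands lowest of the three measured compounds, clearly under compound 2 (`CC(=O)Nc1cc(-c2ccc(OC[C@@H](N)CC(C)C)c(C)c2)ccn1`) at 99% remaining and compound 3 (`CC(=O)Nc1cc(-c2ccc(OC[C@@H](N)CC(C)C)c(Cl)c2)ccn1`) at 100% remaining. Compound 4 (`COC(=O)Nc1cc(-c2cnc(OC[C@@](C)(N)CC(C)C)c(C#N)c2)ccn1`) has not yet been measured. It carries cyano in place of chloro on an aromatic carbon, ortho to a (2-amino-2,4-dimethylpentyl)oxy group, and the difference from compound 1 counts out as cyano in place of chloro on an aromatic carbon with the rest of the core of compound 1 unchanged.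

Within the data shown here, only one measured step bears on this change, and only loosely. It is a number 1 percentage points higher from compound 2 to compound 3 (within the scatter) for chloro in place of methyl on an aromatic carbon. Among the measured compounds shown here, compounds 2 and 3 also differ from compound 1 in other places, and no measured pair exchanges chloro for cyano. For the measured compounds named here, with that single small step as the only guide, no shift beyond the scatter is expected in this assay and a slight upward lean remains an unsupported possibility. The estimated step is a number 6 percentage points higher from compound 1 to compound 4 (within the scatter) and would stay within the scatter. For compound 4 the expected value is 79% remaining, with 62% to 95% as the estimated range.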

Compound 4, percent of the compound remaining: 80%
The estimate for compound 4 lay 1 percentage points below the measured number; low and high end bracket the measured number.
By their numbers in this assay, from the lowest: compounds 1 and 4 (each within the scatter of the next); then compounds 2 and 3 (each within the scatter of the next).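

In this assay, replacing chloro with cyano on an aromatic carbon, ortho to a (2-amino-2,4-dimethylpentyl)oxy group, gives a number 7 percentage points higher from compound 1 to compound 4 (within the scatter). Among these compounds, this is the first direct pair for the position: on this six-membered aromatic ring with 1 nitrogen, the single chlorine atom can give way to a cyano group of 2 heavy atoms, with its triple bond and hydrogen-bond acceptor, with no shift beyond the scatter in the percent of compound remaining. The earlier step from methyl to chloro came from a different pair of compounds and could not show this, and no evidence is available that would explain the result.

The compounds shown leave open whether this tolerance extends to other groups at this place, such as an amine, a carboxylic acid or a methoxy group, since chloro and cyano are the only two compared here on the core of compound 1. They also leave open whether a longer chain in place of the (2-amino-2,4-dimethylpentyl)oxy group would alter the number for a compound carrying cyano at this position.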